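The compounds below may be only part of what the source reports. "The series", "measured", "known", "first", "only" and "open" are said of these compounds alone.

Measured compounds:
- compound 1, `O=c1oc2ccccc2cc1-c1cn2nc(Cc3ccc(Cl)cc3)sc2n1`: in an ADME assay on CCRF-CEM cells (Homo sapiens) for cytotoxicity, with a stated time of 72 h (a lower number here means a stronger inhibitor, a higher number a weaker inhibitor), compound 1 gives > 10000 nM, which is a limit of the assay.
- compound 2, `Fc1ccc(-c2nc3sc(Cc4ccc(Cl)cc4)nn3c2Br)cc1`: in this assay compound 2 gives > 250000 nM, which is a limit of the assay and not a number.

Compound 2 therefore has no numeric value in this assay; its result is the limit of > 250000 nM in this assay, at which 1 of the 2 values shown sits. Compound 1 likewise sits at a limit, (the limit of > 10000 nM in this assay, at which 1 of the 2 values shown sits), so the two compounds cannot be ranked against each other, and nothing beyond the scatter can be said of the gap between them.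

Compound 3, `O=[N+]([O-])c1ccc(-c2nc3sc(Cc4ccc(Cl)cc4)nn3c2Br)cc1`, differs from compound 2 in one place: nitro in place of fluoro on an aromatic carbon. Among the compounds with values here, no step between measured compounds in this assay is known, so there is no measured precedent for this change. The expectation for compound 3 in this assay is that it remains in the same region as compound 2, with no step beyond the scatter, so a number no higher from compound 2 to compound 3 (the limit leaves the size open) is the estimated step. Compound 3 is expected to give about 250000 nM, with a range from 50000 nM to 1000000 nM, and most likely a limit rather than a number.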

Compound 3, half-maximal inhibitory concentration: 73000 nM
Compound 3: the middle estimate sits 3.4-fold (0.53 log units) above what was measured; the measured number falls inside the stated range.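

In this assay, the aromatic carbon para to a large group, on the six-membered aromatic ring of carbon only, is now shown to respond to a single change: nitro in place of fluoro gives an at least 3.4-fold lower number from compound 2 to compound 3 (0.53 log units; beyond the scatter). Within the data shown here, compound 3 gives 73000 nM, the only value that is a number and not a limit, so this position can shift the read-out on the shared core even though compound 3 still needs a high concentration to register. The true size of the step stays open because the value of compound 2 is a limit and not a number: the limit of > 250000 nM in this assay, at which 1 of the 3 values shown sits.

One step at one position cannot show whether the change depends on the nitro group itself or whether another group there, such as an amine, a carboxylic acid or a nitrile, would give a similar number. Going by these compounds, compound 1 differs from compound 3 in more than one place, so it is also open whether the nitro group would have the same effect in another part of the series.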